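The compounds below may be only part of what the source reports. "The series", "measured", "known", "first", "only" and "open" are said of these compounds alone.

Values so far in a functional assay on ZR-75-1 cells (Homo sapiens) for cytotoxicity, read by sulforhodamine B assay, with a stated time of 3 days; a higher number here means that more compound is needed for the effect, a lower number that less compound is needed
compound 1 (`Cc1coc(-c2ccc3c(c2O)CCCC3(C)C)c1C(=O)O`) 1.7 uM
compound 2 (`Cc1coc(-c2ccc3c(c2O)CCCC3(C)C)c1CO`) 25.5 uM

Among the measured compounds shown here, compound 2 holds the higher of the two numbers, and the only measured step is a 15-fold higher number from compound 1 to compound 2 (1.18 log units; beyond the scatter) (large). That step is hydroxymethyl in place of carboxy on an aromatic carbon, so it bears on compound 3 (`COc1c(-c2occ(C)c2CO)ccc2c1CCCC2(C)C`) only loosely. For the measured compounds named here, compound 3 differs from compound 2 by methyl in place of hydrogen on an oxygen on an aromatic ring (hydroxy to methoxy), at a place no measured step has touched. The expected change in this assay is a 1.2-fold higher number from compound 2 to compound 3 (0.07 log units; within the scatter) (none beyond the scatter, with wide uncertainty). Compound 3 is estimated at 30 uM (expected range 10 uM to 90 uM).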

Compound 3, concentration for half-maximal effect: 15 uM
Beside the measured number, compound 3's estimate is 2.0-fold (0.30 log units) above it, within the range that was stated.
By their numbers in this assay, from the lowest: compound 1; then compounds 3 and 2 (each within the scatter of the next).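

In this assay, hydroxy to methoxy gives a 1.7-fold lower number from compound 2 to compound 3 (0.23 log units; within the scatter), so this change at the oxygen on the aromatic ring stays within the scatter. On the hydroxymethyl compounds, then, the hydrogen on that oxygen can be replaced by methyl without a step beyond the scatter. No available evidence gives a reason for this result. Open, going by these compounds, is whether a longer chain on that oxygen, such as ethoxy, or an amine in place of the hydroxy, would also stay within the scatter. Also open, on these data alone, is whether methoxy behaves the same alongside the carboxy of compound 1.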